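Swapping a tert-butylphenyl for a naphthyl on the core

The source may hold more compounds than are shown below. What is called first, only, known or untested is meant among the compounds shown, and "the series" means these compounds.

Compound 3 `CC(C)(C)c1ccc(-c2nc3sccn3c2/C=N/OCc2ccc(Cl)c(Cl)c2)cc1` gives the highest number of the three measured compounds in an assay on HepG2 cells for agonist activity at nuclear receptor subfamily 1 group I member 3 (Homo sapiens), read by a luciferase reporter, with a stated time of 23 h (a higher number here means that more compound is needed for the effect, a lower number that less compound is needed), namely 2400 nM. Compound 1 `Clc1ccc(CO/N=C/c2c(-c3ccc(Br)cc3)nc3sccn23)cc1Cl` gives 480 nM in this assay, and compound 2 `Clc1ccc(CO/N=C/c2c(-c3ccccc3)nc3sccn23)cc1Cl` gives 580 nM. Compound 4 `Clc1ccc(CO/N=C/c2c(-c3ccc4ccccc4c3)nc3sccn23)cc1Cl` is not yet measured; it differs from compound 3 in one place: naphthalen-2-yl in place of 4-(tert-butyl)phenyl on an aromatic carbon. For the measured compounds named here, two measured steps bear on this change: a 5.0-fold higher number from compound 1 to compound 3 (0.70 log units; beyond the scatter) and a 4.1-fold higher number from compound 2 to compound 3 (0.62 log units; beyond the scatter), both showing that the tert-butyl group came with a higher number, while a 1.2-fold higher number from compound 1 to compound 2 (0.08 log units; within the scatter). Going by the values given here, removing the tert-butyl group is therefore expected to bring the number down, but the entering second ring has no measured precedent here, so the expected step of a 2.4-fold lower number from compound 3 to compound 4 (0.38 log units; beyond the scatter) is only a modest decrease. Compound 4 is estimated at 1000 nM, within the range 300 nM to 4000 nM.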

Compound 4, half-maximal effective concentration: 380 nM
Compound 4: middle estimate off by 2.6-fold (0.42 log units), on the high side; the measured number falls inside the stated range.
By their numbers in this assay, from the lowest: compounds 4, 1 and 2 (each within the scatter of the next); then compound 3.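

At this position on the shared core, the two fused rings of naphthalen-2-yl are tolerated in this assay, with no change beyond the scatter: a 1.5-fold lower number from compound 2 to compound 4 (0.18 log units; within the scatter) and a 1.3-fold lower number from compound 1 to compound 4 (0.10 log units; within the scatter). The heavy-atom count alone therefore does not set the number, since 4-(tert-butyl)phenyl and naphthalen-2-yl have the same count, yet the exchange gives a 6.3-fold lower number from compound 3 to compound 4 (0.80 log units; beyond the scatter). Nothing available here explains the difference between these two groups. On these data alone, what an amine or a carboxylic acid at this position would do remains open.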